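Pyridinyl diazabicycles: methoxy substitution at compound 2

The compounds below may be only part of what the source reports. "The series", "measured", "known", "first", "only" and "open" are said of these compounds alone.

Measured so far:
compound 1 `c1cncc(N2CC[C@H]3CN[C@H]3C2)c1` — 71 nM
compound 2 `c1cncc(N2CC[C@@H]3CN[C@@H]3C2)c1` — 330 nM
compound 3 `N#Cc1cncc(N2CC[C@@H]3CN[C@@H]3C2)c1` — 1900 nM

In a functional assay on HEK293 cells for agonist activity at Neuronal acetylcholine receptor; alpha4/beta2 (Homo sapiens), read by FLIPR (on this read-out lower numbers stand for an effect already at smaller amounts and higher numbers for an effect only at larger amounts of compound), compound 2 gives 330 nM, the second highest of the three numbers. Its nearest neighbour is compound 1, with a 4.6-fold higher number from compound 1 to compound 2 (0.67 log units; beyond the scatter) separating them; the fact that compounds 1 and 2 differ only in the configuration as drawn is the only structural difference in that pair. The furthest is compound 3, reached by a 5.8-fold higher number from compound 2 to compound 3 (0.76 log units; beyond the scatter).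

Compound 4 `COc1ccc(N2CC[C@@H]3CN[C@@H]3C2)cn1` is not yet measured. It differs from compound 2 by methoxy in place of hydrogen on an aromatic carbon. Within the data shown here, the only measured step that touches a substituent on the aromatic ring is the one from compound 2 to compound 3, a cyano in place of hydrogen, which gave a 5.8-fold higher number from compound 2 to compound 3 (0.76 log units; beyond the scatter). Compound 4 carries a methoxy instead, at a different place on the ring, so that step is a loose guide at best; a modest shift towards higher numbers, or none beyond the scatter, is the expectation.

For compound 4 in this assay the estimate is 650 nM, within 150 nM to 3000 nM, which corresponds to an expected step of a 2.0-fold higher number from compound 2 to compound 4 (0.29 log units; within the scatter).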

Compound 4, half-maximal effective concentration: 4980 nM
Compound 4: middle estimate off by 7.7-fold (0.88 log units), on the low side, and the stated range ends below it.
By their numbers in this assay, from the lowest: compound 1; then compound 2; then compound 3; then compound 4.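

In this assay methoxy on the aromatic carbon next to the ring nitrogen, para to a group of 8 heavy atoms, brings a large rise in the number (a 15-fold higher number from compound 2 to compound 4 (1.18 log units; beyond the scatter)), so this place on the ring of compound 2 does not take this group without a clear loss. Together with the cyano change at a different place on the ring (a 5.8-fold higher number from compound 2 to compound 3 (0.76 log units; beyond the scatter)), both ring substitutions shown on compound 2 move the number in the same direction, with the methoxy step printed as large and the cyano step as modest. Nothing measured here bears on the cause of the methoxy step.

From the compounds shown here alone, whether fluorine, methyl or an amine at this same place would stay closer to compound 2 remains open. Also open, going by these compounds, is whether methoxy at this place would do the same on compound 1.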